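The source may report more compounds than this note shows. Statements on the series, on what has been measured and on what is new or still open speak of the compounds shown alone.

Compound 1 `COC(=O)/C=C/c1cccc(N(Cc2ccc(/C=C/c3cccc(F)c3)cc2)C(=O)C2CCCCC2)c1` and compound 2 `COC(=O)/C=C/c1cccc(N(Cc2ccc(/C=C/c3ccccn3)cc2)C(=O)C2CCCCC2)c1` share one core and differ only in the aromatic ring on a double-bonded chain carbon bound to a double-bonded chain carbon. In an assay on isolated protein with Bile acid receptor (Homo sapiens) as the target (a lower number here means that less compound is needed, a higher number that more compound is needed for the effect), compound 1 gives 86 nM, and compound 2 gives 309 nM. The single step shown so far, a 3.6-fold higher number from compound 1 to compound 2 (0.56 log units; beyond the scatter), swaps 3-fluorophenyl for pyridin-2-yl. On the numbers shown, compound 2 stands at the higher end of the two, with compound 1 as its only neighbour.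

Compound 3 `COC(=O)/C=C/c1cccc(N(Cc2ccc(/C=C/c3scnc3C)cc2)C(=O)C2CCCCC2)c1` takes this further by 4-methyl-1,3-thiazol-5-yl in place of pyridin-2-yl on a double-bonded chain carbon bound to a double-bonded chain carbon. Among the measured compounds shown here, no measured step covers a thiazole ring at this place; the only guidance is that changing this ring between compound 1 and compound 2 moved the number by a modest amount, a 3.6-fold higher number from compound 1 to compound 2 (0.56 log units; beyond the scatter), so a change of similar size in either direction is plausible, and a step hidden within the scatter cannot be ruled out. The step from compound 2 to compound 3 in this assay is therefore expected to be about a 1.0-fold lower number from compound 2 to compound 3 (0.01 log units; within the scatter). Compound 3 is estimated at 300 nM, with a range from 90 nM to 1000 nM.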

Compound 3, half-maximal effective concentration: 227 nM
Compound 3: the middle estimate sits 1.3-fold (0.12 log units) above what was measured, within the range that was stated.
By their numbers in this assay, from the lowest: compound 1; then compounds 3 and 2 (each within the scatter of the next).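

In this assay the five-membered 4-methyl-1,3-thiazol-5-yl ring and the six-membered pyridin-2-yl ring cannot be told apart, with a 1.4-fold lower number from compound 2 to compound 3 (0.13 log units; within the scatter) even though the ring size and the number of hetero atoms and hydrogen-bond acceptors all differ. The 3-fluorophenyl ring of compound 1 remains separate from both, with a 2.6-fold higher number from compound 1 to compound 3 (0.42 log units; beyond the scatter) alongside the earlier 3.6-fold higher number from compound 1 to compound 2 (0.56 log units; beyond the scatter) so that at this place, on a double-bonded chain carbon bound to a double-bonded chain carbon, two different nitrogen-containing rings now give higher numbers than the 3-fluorophenyl ring. Nothing available here explains why the numbers fall this way.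

The rings shown at this place are all aromatic, so it remains open how a saturated ring such as piperidine or morpholine, or a carboxylic acid, would behave there. A plain 1,3-thiazol-5-yl ring without the methyl group would show whether that methyl matters to the number.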